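The source may report more compounds than this note shows. Statements on the series, on what has been measured and on what is new or still open speak of the compounds shown alone.

Among the compounds with values here, in an ADME assay on microsomes from liver (Mus musculus) for metabolic stability, read by LC-MS (a lower number here means that the compound disappears faster, a higher number that the compound lasts longer), compound 1 `O=C(Nc1ccc(F)c(-c2nc3ncc(-c4ccc(F)c(F)c4)cc3[nH]2)c1)N1CCCC1` gives 0.08 h and compound 2 `O=C(Nc1ccc(F)c(-c2nc3ncc(-c4ccc(F)cc4)cc3[nH]2)c1)N1CCCC1` gives 0.095 h, so compound 1 stands level with the only other compound measured. Compound 3 `O=C(Nc1ccc(F)c(-c2nc3ncc(-c4ccccc4F)cc3[nH]2)c1)N1CCCC1` is still unmeasured. It carries 2-fluorophenyl in place of 3,4-difluorophenyl on an aromatic carbon. Within the data shown here, one measured step bears on this, the loss of a fluoro from that same group: a 1.2-fold higher number from compound 1 to compound 2 (0.07 log units; within the scatter), within the scatter. Among the measured compounds shown here, no measured compound carries 2-fluorophenyl, so this guide is only partial. The expected change is a 1.3-fold higher number from compound 1 to compound 3 (0.10 log units; within the scatter), nothing beyond the scatter. For compound 3, the estimated half-life is 0.1 h, with an expected range of 0.05 h to 0.2 h.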

Compound 3, half-life: 0.172 h
For compound 3 the middle estimate is 1.7-fold (0.24 log units) below the measured one, within the range that was stated.
By their numbers in this assay, from the lowest: compounds 1, 2 and 3 (each within the scatter of the next, the first and the last beyond it).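

In this assay, within the data shown here, the change from 3,4-difluorophenyl to 2-fluorophenyl gives a 2.2-fold higher number from compound 1 to compound 3 (0.33 log units; beyond the scatter) and is the first step in this set to pass the scatter, though only modestly. Putting 2-fluorophenyl in place of 4-fluorophenyl gives a 1.8-fold higher number from compound 2 to compound 3 (0.26 log units; within the scatter) and stays within the scatter, so that swap alone shows no clear change. Nothing available here explains the difference between these fluorine patterns. Still open, as far as these compounds go, is how this position would respond to a phenyl ring with no fluorine at all, a methoxy group or a pyridine ring.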